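Swapping the cyanopyridine for a chlorophenyl on the shared core

The source may report more compounds than this note shows. Statements on the series, on what has been measured and on what is new or still open speak of the compounds shown alone.

Of the compounds shown here, three with a common core have been tested in a functional assay on BJAB cells (Homo sapiens) for antiproliferative activity, with a stated time of 4 days; on this read-out lower numbers stand for an effect already at smaller amounts and higher numbers for an effect only at larger amounts of compound. Compound 1 `CCSc1sc(-n2nc(C)c(Cc3ccccc3[N+](=O)[O-])c2C(=O)O)nc1-c1ccc(Cl)c(Cl)c1` gives 59000 nM. Compound 2 `Cc1nn(-c2nc(-c3ccc(Cl)c(Cl)c3)c(SC(C)C)s2)c(C(=O)O)c1-c1cncc(C#N)c1` gives 20000 nM, the lowest of the two numbers, and its nearest neighbour is compound 1 with a higher number that lies beyond the usual scatter. For compound 3 `Cc1oncc1-c1nc(-n2nc(C(=O)O)c(-c3cc(Cl)cc(Cl)c3)c2C)sc1SC(C)C` the assay reports only a limit, > 44000 nM, which is the upper end of the measured range (the limit of > 44000 nM in this assay, at which 1 of the 3 values shown sits). Compound 4 `Cc1nn(-c2nc(-c3ccc(Cl)c(Cl)c3)c(SC(C)C)s2)c(C(=O)O)c1-c1cccc(Cl)c1` has not been measured. It differs from compound 2 by 3-chlorophenyl in place of 5-cyanopyridin-3-yl on an aromatic carbon. Going by the values given here, no measured pair shows a change of this kind, so its size is unknown. The expected step is small, roughly within the scatter, a 1.3-fold lower number from compound 2 to compound 4 (0.12 log units; within the scatter). Compound 4 is therefore estimated at 15000 nM, with a range from 4000 nM to 50000 nM.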

Compound 4, half-maximal effective concentration: 13600 nM
Compound 4: middle estimate off by 1.1-fold (0.04 log units), on the high side; the measured number falls inside the stated range.
By their numbers in this assay, from the lowest: compounds 4 and 2 (each within the scatter of the next); then compound 1.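

In this assay replacing 5-cyanopyridin-3-yl with 3-chlorophenyl gives a 1.5-fold lower number from compound 2 to compound 4 (0.17 log units; within the scatter) and so the two compounds read alike. On this aromatic carbon, next to the ring atom that bears a carboxy group, the nitrile and the ring nitrogen can therefore both be absent with no shift beyond the scatter. No measurement shown gives a reason for this.

On these data alone, whether an amine or a carboxylic acid at this position would read differently stays open. So does whether any group here could bring the number much lower.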